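Cyclohexyl on the amine nitrogen of compound 4

The source may report more compounds than this note shows. Statements on the series, on what has been measured and on what is new or still open speak of the compounds shown alone.

In a functional assay on HeLa cells (Homo sapiens) for inhibition, read by sulforhodamine B assay (a lower number here means a stronger inhibitor, a higher number a weaker inhibitor), compound 3 `O=C1C=C(Nc2ccccc2F)C(=O)c2c1nc1n2[C@H]2OC[C@@H](O)[C@H]2OC1` gives 5120 nM, within the scatter of compound 1 `CCCc1ccc(NC2=CC(=O)c3nc4n(c3C2=O)[C@H]2OC[C@@H](O)[C@H]2OC4)cc1` at 4990 nM. Compound 2 `O=C1C=C(N2CCC2)C(=O)c2c1nc1n2[C@H]2OC[C@@H](O)[C@H]2OC1` reads > 16000 nM, which is a limit of the assay. Compound 4 `O=C1C=C(NC2CCCCC2)C(=O)c2c1nc1n2[C@H]2OC[C@@H](O)[C@H]2OC1` carries cyclohexyl in place of 2-fluorophenyl on an amine nitrogen. Going by the values given here, two measured steps bear on this change. Exchanging 4-propylphenyl for 2-fluorophenyl gave a 1.0-fold higher number from compound 1 to compound 3 (0.01 log units; within the scatter). Exchanging azetidin-1-yl for (2-fluorophenyl)amino gave an at least 3.1-fold lower number from compound 2 to compound 3 (0.49 log units; beyond the scatter). Neither step tests a non-aromatic ring on the amine nitrogen, so the reading in this assay is uncertain. The expected step, a 1.4-fold higher number from compound 3 to compound 4 (0.14 log units; within the scatter), stays within the scatter, with a higher number the likelier side. For compound 4 the estimated value is 7000 nM, with an expected range of 3000 nM to 16000 nM.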

Compound 4, half-maximal inhibitory concentration: > 16000 nM
Compound 4 gave a limit, no number; the forecaster's own chance of this, stated with the estimate: 25%; middle value at least 2.2-fold (0.35 log units) away from the limit.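

In this assay, the group on the amine nitrogen now makes a difference: cyclohexyl in place of 2-fluorophenyl gives an at least 3.1-fold higher number from compound 3 to compound 4 (0.49 log units; beyond the scatter), and cyclohexyl in place of 4-propylphenyl gives an at least 3.2-fold higher number from compound 1 to compound 4 (0.50 log units; beyond the scatter), whereas the two aromatic groups alone showed no separation. The reading for compound 4 is a limit and not a number, so both steps give only a smallest size. The step linking compound 2 and compound 4 joins two limits and cannot be read.

From the compounds shown here alone, whether a benzyl group on the amine nitrogen would read like the aromatic groups or like cyclohexyl remains open. So does the true size of the loss with cyclohexyl.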